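The source may hold more compounds than are shown below. What is called first, only, known or untested is meant among the compounds shown, and "the series" means these compounds.

Values in a functional assay on CCRF-CEM cells (Homo sapiens); on this read-out lower numbers stand for higher toxicity in this test and higher numbers for lower toxicity in this test:
- compound 1 `CC(=O)NC1=CS(=O)(=O)O[C@@]12[C@@H](CO[Si](C)(C)C(C)(C)C)O[C@@H](n1cc(C)c(=O)n(C)c1=O)[C@@H]2O[Si](C)(C)C(C)(C)C`: 25700 nM
- compound 2 `Cc1cn([C@@H]2O[C@H](CO[Si](C)(C)C(C)(C)C)[C@@]3(OS(=O)(=O)C=C3NC(N)=O)[C@H]2O[Si](C)(C)C(C)(C)C)c(=O)n(C)c1=O`: 4360 nM
- compound 3 `Cc1cn([C@@H]2O[C@H](CO[Si](C)(C)C(C)(C)C)[C@@]3(OS(=O)(=O)C=C3NC(=O)c3ccccc3)[C@H]2O[Si](C)(C)C(C)(C)C)c(=O)n(C)c1=O`: 4910 nM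

Compound 3 is level with compound 2 (a 1.1-fold higher number from compound 2 to compound 3 (0.05 log units; within the scatter)). Both have lower numbers than compound 1 (a 5.2-fold lower number from compound 1 to compound 3 (0.72 log units; beyond the scatter) and a 5.9-fold lower number from compound 1 to compound 2 (0.77 log units; beyond the scatter)).

The next step leads to compound 4 `Cc1cn([C@@H]2O[C@H](CO[Si](C)(C)C(C)(C)C)[C@@]3(OS(=O)(=O)C=C3NCC(=O)C(N)=O)[C@H]2O[Si](C)(C)C(C)(C)C)c(=O)n(C)c1=O`, with (carbamoylcarbonyl)methyl in place of benzoyl on an amine nitrogen.

Among the measured compounds shown here, no measured step makes this exact change. All three replace one group on a carbonyl carbon with another, and that carbonyl stays on the amine nitrogen, whereas in compound 4 it does not. They therefore offer only a rough guide to size: two are modest and the third lies within the scatter. The entering group has no ring, as in compound 1 and compound 2, yet those two differ (a 5.9-fold lower number from compound 1 to compound 2 (0.77 log units; beyond the scatter)), so the absence of a ring does not settle the direction. With compound 3 at the low end of the measured span, a modest move towards a higher number is the tentative expectation, and no change beyond the scatter remains possible.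

The expected change in this assay is a 1.6-fold higher number from compound 3 to compound 4 (0.21 log units; within the scatter).

For compound 4 the estimated value is 8000 nM, with an expected range from 2800 nM to 25000 nM.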

Compound 4, half-maximal cytotoxic concentration: 9960 nM
Compound 4: middle estimate off by 1.2-fold (0.10 log units), on the low side; the measured number falls inside the stated range.
By their numbers in this assay, from the lowest: compounds 2 and 3 (each within the scatter of the next); then compound 4; then compound 1.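

Among the compounds shown here, compound 4 is the first without a carbonyl carried directly on the amine nitrogen, and this change does not take the number outside the span set by the acetyl, carbamoyl and benzoyl compounds in this assay. The result places (carbamoylcarbonyl)methyl at an intermediate level, with modest steps in both directions: upward against the benzoyl and carbamoyl groups (a 2.0-fold higher number from compound 3 to compound 4 (0.31 log units; beyond the scatter)) (a 2.3-fold higher number from compound 2 to compound 4 (0.36 log units; beyond the scatter)) and downward against the acetyl group (a 2.6-fold lower number from compound 1 to compound 4 (0.41 log units; beyond the scatter)). No measurement here bears on why this position responds in this way.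

For the compounds shown here, with only one group of this kind on the amine nitrogen, the series cannot separate the removal of the directly attached carbonyl from the gain of the carbamoylcarbonyl portion of the entering group. On these data alone, whether an unsubstituted amine, a simple ethyl chain or a longer chain ending in a carboxylic acid on the same nitrogen would stay within this span in this assay remains open, as does whether any such group would give a number above that of compound 1 (25700 nM).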